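From methyl to cyano: a step among limits

The source may hold more compounds than are shown below. What is called first, only, known or untested is meant among the compounds shown, and "the series" means these compounds.

Measured so far in an ADME assay on RAW264.7 cells (Mus musculus) for cytotoxicity, read by MTT assay, with a stated time of 24 h, in the presence of a further agent that is not named here (a lower number here means a stronger inhibitor, a higher number a weaker inhibitor), as follows:
- compound 1 `COc1cc(OC)c2c(c1)C(C(O)c1ccc(OCc3ccccc3)cc1)OC2=O` gives > 40000 nM
- compound 2 `COc1cc(OC)c2c(c1)C(C(O)c1ccc(OCc3ccc(Br)cc3)cc1)OC2=O` gives > 40000 nM
- compound 3 `COc1cc(OC)c2c(c1)C(C(O)c1ccc(OCc3ccc(C)cc3)cc1)OC2=O` gives > 40000 nM

Each of these entries is a limit of the assay and not a number. Compound 3 stands at the limit > 40000 nM and therefore has no exact value. It has company, since the limit of > 40000 nM in this assay, at which 3 of the 3 values shown sit, is all that the series shows so far.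

Compound 4 `COc1cc(OC)c2c(c1)C(C(O)c1ccc(OCc3ccc(C#N)cc3)cc1)OC2=O` differs from compound 3 in one place, with cyano in place of methyl on an aromatic carbon, para to a large group cyano in place of methyl on an aromatic carbon and the rest of the structure unchanged.

Going by the values given here, three measured steps bear on this change, all made at that same place. They are a step that the two limits leave unreadable from compound 1 to compound 2 and a step that the two limits leave unreadable from compound 1 to compound 3 and also a step that the two limits leave unreadable from compound 2 to compound 3 as the closest case. None of them has a readable size, so they point in no direction. Hydrogen, bromo and methyl all end at the limit, so no step beyond the usual scatter is expected, and another limit is the likeliest report.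

The expected change is a number no higher from compound 3 to compound 4 (the limit leaves the size open) in this estimate. For compound 4 the estimated value is 40000 nM in this assay with an expected range from 25000 nM to 80000 nM as its ends.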

Compound 4, half-maximal inhibitory concentration: > 40000 nM
Compound 4 gave a limit, no number (the forecaster's own chance of this, stated with the estimate: 85%); the middle value lies on the limit itself.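

Compound 4 also gives a limit, > 40000 nM, and not a number, so its steps from compound 1, compound 2 and compound 3 cannot be read. The compounds shown leave open what exact value any of them has in this assay, and whether any group at this place would give a readable number, since all rest at one limit: the limit of > 40000 nM in this assay, at which 4 of the 4 values shown sit.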